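The source may report more compounds than this note shows. Statements on the series, on what has been measured and on what is new or still open speak of the compounds shown alone.

Compound 2 `O=C(Nc1ccccc1)Nc1nc(Sc2c[nH]c3ccccc23)cc(N2CCN(Cc3ccccc3)CC2)n1` is measured in a functional assay on A549 cells (Homo sapiens) for inhibition, with a stated time of 72 h; a higher number here means a weaker inhibitor, a lower number a stronger inhibitor. In this assay compound 2 reaches only the limit > 50000 nM, which is a boundary of the assay and not a number. Compound 1 `Cc1cc(Cl)ccc1NC(=O)Nc1nc(Sc2c[nH]c3ccccc23)cc(N2CCN(Cc3ccccc3)CC2)n1` likewise gives in this assay the limit > 50000 nM. Compound 3 `COc1ccc(NC(=O)Nc2nc(Nc3cc(OC)cc(OC)c3)cc(Sc3c[nH]c4ccccc34)n2)cc1` also gives the limit > 50000 nM. Among the measured compounds shown here, the one change that has been made, a step that the two limits leave unreadable from compound 1 to compound 2, cannot be read in size, since both of its ends sit at the limit of > 50000 nM in this assay, at which 3 of the 3 values shown sit. Compound 4 `Cc1ccc(C)c(NC(=O)Nc2nc(Sc3c[nH]c4ccccc34)cc(N3CCN(Cc4ccccc4)CC3)n2)c1` carries 2,5-dimethylphenyl in place of phenyl on an amide-type nitrogen. For the measured compounds named here, no measured step of readable size bears on this change, and every value shown sits at the same limit, so no step beyond the scatter is expected. The step of a number no higher from compound 2 to compound 4 (the limit leaves the size open) is therefore expected to be about none. Compound 4 is estimated at 50000 nM, between 20000 nM and 100000 nM, and is expected most likely to be reported again only as a limit.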

Compound 4, half-maximal inhibitory concentration: > 50000 nM
Compound 4: a limit, no number (the forecaster's own chance of this, stated with the estimate: 85%); the middle value lies on the limit itself.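

Compound 4 ends at a limit of the assay, as do compound 1 and compound 2, so the steps from compound 2 and compound 1 to compound 4 cannot be read in size: the limit of > 50000 nM in this assay, at which 4 of the 4 values shown sit. The compounds shown leave open whether changing the group on the amide-type nitrogen alters inhibition at all in this assay.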